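The source may hold more compounds than are shown below. What is called first, only, known or untested is meant among the compounds shown, and "the series" means these compounds.

Measured in a functional assay on PK9 cells (Homo sapiens) for inhibition, read by MTT assay, with a stated time of 72 h; a lower number here means a stronger inhibitor, a higher number a weaker inhibitor:
Compound 1 `CCCCCC/C=C/CCCCCCCCOC[C@H]1NC[C@H](O)[C@@H]1O`: > 100000 nM
Compound 2 `C=CCCCCCCCCCOC[C@@H]1CCCN1C(=O)OC(C)(C)C`: > 100000 nM

Both entries are limits of the assay and not numbers. Compound 2 therefore has no exact place on the scale and stands at the limit of > 100000 nM in this assay, at which 2 of the 2 values shown sit. Compound 3 `CCCCCCCC/C=C/CCCCCCCCOC[C@@H]1CCCN1C(=O)OC(C)(C)C` keeps the core of compound 2 and changes only the end of the chain: a group of 10 heavy atoms (10 carbon; no ring) in place of a group of 3 heavy atoms (3 carbon; no ring), on a saturated chain carbon, eight bonds along the chain from an oxygen on a saturated carbon. In words, a group of 10 heavy atoms replaces a group of 3 heavy atoms, on a saturated chain carbon, eight bonds along the chain from an oxygen on a saturated carbon. For the measured compounds named here, no measured pair shows the effect of such a change in this assay. At most a modest move towards stronger inhibition is expected, and compound 3 may well remain at the limit. The estimated step is an at least 1.4-fold lower number from compound 2 to compound 3 (0.15 log units; that floor lies within the scatter). For compound 3 the estimated value is 70000 nM, with an expected range of 20000 nM to 150000 nM.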

Compound 3, half-maximal inhibitory concentration: > 100000 nM
Compound 3 gave a limit, no number; the forecaster's own chance of this, stated with the estimate: 60%; at least 1.4-fold (0.15 log units) between middle value and limit.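

For the compounds shown here, compound 2 and compound 3 both give only limits and not numbers, and no step between them can be read: the limit of > 100000 nM in this assay, at which 3 of the 3 values shown sit.

None of the compounds shown gives a number in this assay, which leaves open whether replacing the allyl group with the group of 10 heavy atoms changes inhibition at all.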